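This account rests on a few compounds, and the source may have more. Where it says the series, first, only, none or still open, it means among the compounds named here.

Compound 1 `O=C(/C=C/CN1CCCCC1)Nc1cc2c(N3CCc4ccccc43)ncnc2cc1O[C@@H]1CCOC1` and compound 2 `CN1CCN(C/C=C/C(=O)Nc2cc3c(N4CCc5ccccc54)ncnc3cc2O[C@@H]2CCOC2)CC1` share one core, while compound 3 `COc1cc2ncnc(N3CCCc4ccccc43)c2cc1NC(=O)/C=C/CN1CCCCC1` and compound 4 `COc1cc2ncnc(N3CCCc4ccccc43)c2cc1NC(=O)/C=C/CN1CCN(C)CC1` share another; the difference between the two cores is not broken down here. In a functional assay on MCF7 cells (Homo sapiens) for antiproliferative activity, read by MTT assay, with a stated time of 72 h (a lower number here means a stronger inhibitor, a higher number a weaker inhibitor), compound 1 gives 1890 nM, compound 2 gives 5350 nM, and compound 3 gives 3930 nM. The change from compound 1 to compound 2 is 4-methylpiperazin-1-yl in place of piperidin-1-yl on a saturated chain carbon bound to a double-bonded chain carbon, and it produced a 2.8-fold higher number from compound 1 to compound 2 (0.45 log units; beyond the scatter). The same change appears from compound 3 to compound 4 as 4-methylpiperazin-1-yl in place of piperidin-1-yl on a saturated chain carbon bound to a double-bonded chain carbon, at the same place on the chain. Within the data shown here, compound 4 is expected to show a step of about a 2.5-fold higher number from compound 3 to compound 4 (0.41 log units; beyond the scatter) in this assay, because a 2.8-fold higher number from compound 1 to compound 2 (0.45 log units; beyond the scatter) is the only measured instance of this change and rests on a single pair. On that basis compound 4 is estimated at 10000 nM, within a range from 4500 nM to 22000 nM.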

Compound 4, half-maximal inhibitory concentration: 8560 nM
The estimate for compound 4 lay 1.2-fold (0.07 log units) above the measured number; low and high end bracket the measured number.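

In this assay, 4-methylpiperazin-1-yl in place of piperidin-1-yl gave a 2.2-fold higher number from compound 3 to compound 4 (0.34 log units; beyond the scatter), and the step agrees with the one on the other core: the same change on two cores in this assay, a 2.8-fold higher number (0.45 log units; beyond the scatter) from compound 1 to compound 2 and a 2.2-fold higher number (0.34 log units; beyond the scatter) from compound 3 to compound 4, 1.3-fold (0.11 log units) apart, within the scatter of two such steps On these two cores, then, the change raises the number in the same direction and by a similar amount. Among these compounds, this rests on only two pairs in a single assay, so it does not show that the step would carry over to other cores, and it does not explain why the number rises.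

The compounds shown leave open how a morpholin-4-yl or a dimethylamino group would compare with piperidin-1-yl at the same place on the chain. They also leave open whether either would follow the same direction on both cores.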